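This account rests on a few compounds, and the source may have more. Where it says the series, first, only, none or still open, it means among the compounds named here.

Among the compounds with values here, in a functional assay on MCF7 cells (Homo sapiens) for inhibition (a lower number here means a stronger inhibitor, a higher number a weaker inhibitor), compound 2 `CC/C(=C(/c1ccc(/C=C/C(=O)O)cc1)c1cc2ccccc2[nH]1)c1ccccc1Cl` gives 42 nM, the lowest of the three numbers measured so far. Compound 1 `CC/C(=C(/c1ccc(/C=C/C(=O)O)cc1)c1cc2ccccc2[nH]1)c1ccccc1` gives 108 nM in this assay, and compound 3 `CC/C(=C(/c1ccc(/C=C/C(=O)O)cc1)c1cc2ccccc2[nH]1)c1ccc(Cl)cc1` gives 343 nM. The two single changes from compound 1 run in opposite directions: a 2.6-fold lower number from compound 1 to compound 2 (0.41 log units; beyond the scatter) against a 3.2-fold higher number from compound 1 to compound 3 (0.50 log units; beyond the scatter), and the direct comparison shows an 8.2-fold higher number from compound 2 to compound 3 (0.91 log units; beyond the scatter). Compound 4 `CC/C(=C(/c1ccc(/C=C/C(=O)O)cc1)c1cc2ccccc2[nH]1)c1ccc(Cl)cc1C#N` has not yet been measured; it differs from compound 2 in one place: 4-chloro-2-cyanophenyl in place of 2-chlorophenyl on a double-bonded chain carbon bound to a double-bonded chain carbon and a saturated chain carbon. Within the data shown here, the entering group carries the chlorine arrangement of the 4-chlorophenyl in compound 3 together with a nitrile that has no counterpart among the measured compounds. The step of an 8.2-fold higher number from compound 2 to compound 3 (0.91 log units; beyond the scatter) therefore bears most directly on this change, with a 3.2-fold higher number from compound 1 to compound 3 (0.50 log units; beyond the scatter) pointing the same way, while the nitrile adds uncertainty in both directions. A higher number than that of compound 2 is expected, beyond the scatter but likely short of the full step to compound 3. Compound 4 is thus estimated at 200 nM in this assay, with a range from 60 nM to 700 nM. The expected step is a 4.8-fold higher number from compound 2 to compound 4 (0.68 log units; beyond the scatter).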

Compound 4, half-maximal inhibitory concentration: 14 nM
For compound 4 the middle estimate is 14-fold (1.15 log units) above the measured one; measured number below the stated range.
By their numbers in this assay, from the lowest: compound 4; then compound 2; then compound 1; then compound 3.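

In this assay the nitrile more than reverses what the 4-chlorophenyl group shows on its own, with a 25-fold lower number from compound 3 to compound 4 (1.39 log units; beyond the scatter) for the added cyano group, so the high number of compound 3 does not carry over to the 4-chloro-2-cyanophenyl group. This group also outperforms both 2-chlorophenyl, with a 3.0-fold lower number from compound 2 to compound 4 (0.48 log units; beyond the scatter) on exchange, and plain phenyl, with a 7.7-fold lower number from compound 1 to compound 4 (0.89 log units; beyond the scatter) on exchange, so the position on the double-bonded chain carbon accepts the largest of these groups and still gives the lowest number of the four. Nothing measured here accounts for this result.

Going by these compounds, whether a nitrile on the phenyl ring without any chlorine would give a similar step remains open. So does whether an amide or a methoxy group in place of the nitrile would match it.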